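Swapping the Anilide Ring: Predicting Clearance for Compound 4

The source may report more compounds than this note shows. Statements on the series, on what has been measured and on what is new or still open speak of the compounds shown alone.

Compound 1, `CN1C[C@H](C(=O)Nc2ccc(C#N)cc2)[C@@H](c2ccc(/C=C/C(=O)Nc3ccccc3N)cc2)C1`, in an in vitro ADME assay on microsomes from liver (Homo sapiens) for pharmacokinetics, read by LC-MS, with a stated time of 10 min, tested at 1 uM (on this read-out lower numbers stand for slow clearance and higher numbers for fast clearance), gives 1 mL/min/kg.
Compound 2, `CN1C[C@H](C(=O)Nc2cccc(F)c2)[C@@H](c2ccc(/C=C/C(=O)Nc3ccccc3N)cc2)C1`, in this assay gives 6 mL/min/kg.
Compound 3, `Cc1cc(NC(=O)[C@H]2CN(C)C[C@@H]2c2ccc(/C=C/C(=O)Nc3ccccc3N)cc2)ccc1F`, in this assay gives 15 mL/min/kg.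

These three compounds share one core and differ only in the aromatic ring attached to the amide-type nitrogen. Compound 1 shows the lowest number of the three, so it is cleared most slowly; the step of a 6.0-fold higher number from compound 1 to compound 2 (0.78 log units; beyond the scatter) and the step of a 15-fold higher number from compound 1 to compound 3 (1.18 log units; beyond the scatter) both go upward and lie beyond the scatter, and the step of a 2.5-fold higher number from compound 2 to compound 3 (0.40 log units; beyond the scatter) is also upward.

Compound 4, `Cc1ccc(NC(=O)[C@H]2CN(C)C[C@@H]2c2ccc(/C=C/C(=O)Nc3ccccc3N)cc2)cn1`, has not yet been measured. Compared with compound 1 the change is 6-methylpyridin-3-yl in place of 4-cyanophenyl on an amide-type nitrogen. Every measured replacement of the 4-cyanophenyl group has raised clearance, so the expectation for compound 4 is a number higher than that of compound 1, though the two measured steps give only a rough guide to how much. The expected step is a 4.0-fold higher number from compound 1 to compound 4 (0.60 log units; beyond the scatter), in the upward direction, beyond the scatter. Compound 4 is therefore estimated to give 4 mL/min/kg in this assay, within a range from 1.5 mL/min/kg to 12 mL/min/kg.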

Compound 4, clearance: 8 mL/min/kg
Estimate against measurement, compound 4: 2.0-fold (0.30 log units) below, and the stated range covers the measured number.
By their numbers in this assay, from the lowest: compound 1; then compounds 2, 4 and 3 (each within the scatter of the next, the first and the last beyond it).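

Among the rings shown at this amide-type nitrogen, 6-methylpyridin-3-yl is the only one with a hetero atom, and putting it in place of 4-cyanophenyl in this assay still raises the number (an 8.0-fold higher number from compound 1 to compound 4 (0.90 log units; beyond the scatter)). It cannot be told apart from the two fluorine-bearing rings, since both of its other steps lie within the scatter (a 1.3-fold higher number from compound 2 to compound 4 (0.12 log units; within the scatter); a 1.9-fold lower number from compound 3 to compound 4 (0.27 log units; within the scatter)). So 4-cyanophenyl is the one ring of the four that stands apart, and a carbon-only ring does not by itself give the low number, as compound 2 and compound 3 carry carbon-only rings and sit beyond the scatter from compound 1.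

Nothing measured in this set explains why the 4-cyanophenyl ring stands apart. As far as these compounds go, a plain phenyl ring, a phenyl ring carrying an amine or a carboxylic acid, and a pyridine ring carrying a nitrile would help separate what the nitrile contributes from what the ring contributes, and that question stays open here.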